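A few compounds are considered here, and "the series" means these few. Any claim that something is new, unique, unknown or untested is made for them only; others in the source may bear on it.

In a functional assay on T47D cells (Homo sapiens) for inhibition, read by CCK-8 assay, with a stated time of 72 h, tested at 10 uM (a higher number here means more inhibition of growth at the concentration tested, a lower number less inhibition of growth), three compounds sharing one core and differing only in the aromatic group on an amide-type nitrogen have been measured. Compound 1 `CN(C)C(=O)c1cc2cnc(Nc3ccc(NC(=O)C4(C(=O)Nc5ccc(F)cc5)CC4)cc3)nc2n1C1CCCC1` gives 105%, compound 2 `Cc1cccc(NC(=O)C2(C(=O)Nc3ccc(Nc4ncc5cc(C(=O)N(C)C)n(C6CCCC6)c5n4)cc3)CC2)c1` gives 95.3%, and compound 3 `CN(C)C(=O)c1cc2cnc(Nc3ccc(NC(=O)C4(C(=O)Nc5cccc(Cl)c5)CC4)cc3)nc2n1C1CCCC1` gives 92.6%. Compound 3 cannot be told apart from compound 2, as the numbers show a number 2.7 percentage points lower from compound 2 to compound 3 (within the scatter). It does fall short of compound 1, with a number 12.4 percentage points lower from compound 1 to compound 3 (beyond the scatter), though that step is modest.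

The next compound, compound 4 `CN(C)C(=O)c1cc2cnc(Nc3ccc(NC(=O)C4(C(=O)Nc5ccc(Cl)c(C(F)(F)F)c5)CC4)cc3)nc2n1C1CCCC1`, has not yet been measured. Its difference from compound 3 is 4-chloro-3-(trifluoromethyl)phenyl in place of 3-chlorophenyl on an amide-type nitrogen. Put simply, 4-chloro-3-(trifluoromethyl)phenyl stands in place of 3-chlorophenyl on an amide-type nitrogen.

The measured steps at this same place give the best guide. Besides the step to compound 3 already described, there is a number 9.7 percentage points lower from compound 1 to compound 2 (within the scatter). Neither step adds a trifluoromethyl group, so they offer only a loose guide to this change. Still, the largest of them, the step to compound 3, is modest, so no step beyond the scatter is expected in this assay, and no direction is favoured. The expected change is a number 0.6 percentage points lower from compound 3 to compound 4 (within the scatter). For compound 4 the estimated value is 92%, with an expected range from 78% to 104%.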

Compound 4, percent growth inhibition at one concentration: 55.8%
For compound 4 the middle estimate is 36.2 percentage points above the measured one, and the stated range ends above it.
By their numbers in this assay, from the lowest: compound 4; then compounds 3, 2 and 1 (each within the scatter of the next, the first and the last beyond it).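

Among these compounds, compound 4 shows that in this assay the aromatic group on the amide-type nitrogen can matter far more than the earlier compounds suggested, since their swaps at this place were modest at most, whereas this change gives a number 36.8 percentage points lower from compound 3 to compound 4 (beyond the scatter) and counts as large. The fall is just as clear from the other two compounds, with a number 39.5 percentage points lower from compound 2 to compound 4 (beyond the scatter) and a number 49.2 percentage points lower from compound 1 to compound 4 (beyond the scatter), so it does not hang on one particular comparison and sets the 4-chloro-3-(trifluoromethyl)phenyl group apart from all three smaller groups measured so far. No measurement here explains why this group, with its added trifluoromethyl, goes with so much less growth inhibition.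

The compounds shown cannot separate the two features of this group, so a phenyl ring carrying only its trifluoromethyl or only its chloro would be needed to tell whether one of them alone accounts for the fall. They also leave open how this position responds to quite different groups on the ring, such as an amine or a carboxylic acid, or to a plain phenyl.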